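From a Cyclohexyl Amine to a Furanylmethyl Amine

This account rests on a few compounds, and the source may have more. Where it says the series, first, only, none or still open, it means among the compounds named here.

Three compounds built on one shared core have been examined. Compound 1 `O=C(Nc1ccc(N2CCCC2)cc1Cl)c1cc(Cl)ccc1O` was entered into an ADME assay on A549 cells (Homo sapiens) for cytotoxicity, read by LDH release, with a stated time of 15 h (on this read-out lower numbers stand for higher toxicity in this test and higher numbers for lower toxicity in this test), and for compound 1 the entry reads "not determined" (no result reported), so no result was reported for it. Compound 3 `O=C(Nc1ccc(NCCCO)cc1Cl)c1cc(Cl)ccc1O` was entered into the same test, and for compound 3 the entry reads "not determined" (no result reported), again with no result reported. For the measured compounds named here, compound 2 `CC1(Nc2ccc(NC(=O)c3cc(Cl)ccc3O)c(Cl)c2)CCCCC1` is therefore the only member with a number: in this assay compound 2 gives 86500 nM, the sole value available, so it cannot be set against any measured neighbour. Compound 4 `O=C(Nc1ccc(NCc2ccco2)cc1Cl)c1cc(Cl)ccc1O` has not yet been measured. It differs from compound 2 in a single place: (furan-2-yl)methyl in place of 1-methylcyclohexyl on a nitrogen on an aromatic ring. Going by the values given here, with no step between measured compounds to draw on, any expectation for compound 4 rests on compound 2 alone. The change is expected to shift the number only modestly, and the step of a 1.1-fold higher number from compound 2 to compound 4 (0.04 log units; within the scatter) is estimated to stay within the usual scatter, with no direction firmly favoured. Compound 4 is thus expected to give 95000 nM in this assay, with a range from 35000 nM to 250000 nM, and a fair chance remains that only a limit is reported.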

Compound 4, half-maximal cytotoxic concentration: 76300 nM
Beside the measured number, compound 4's estimate is 1.2-fold (0.10 log units) above it; low and high end bracket the measured number.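

In this assay the exchange gives a 1.1-fold lower number from compound 2 to compound 4 (0.05 log units; within the scatter) and so provides a direct comparison at this position, on a nitrogen on an aromatic ring, which the lone number for compound 2 could not. Within this pair, a six-membered non-aromatic ring of carbon only and a five-membered aromatic ring with 1 hetero atom, which brings a hydrogen-bond acceptor, are not told apart by this read-out. No measured evidence is available to explain this result.

This single pair cannot show whether the same holds for other groups on this nitrogen, such as a primary amine or a carboxylic acid at the end of a longer chain. It also leaves open whether a change elsewhere on the shared core would move the number beyond the scatter.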